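Halogenated benzylamine variants on the shared core

The compounds below may be only part of what the source reports. "The series", "measured", "known", "first", "only" and "open" are said of these compounds alone.

Compound 1 `Oc1ccc(CNc2cc(C(F)(F)F)cc3[nH]ncc23)cc1` stands at the top of the two numbers in hand: in an assay for inhibition of Indoleamine 2,3-dioxygenase 1 (Homo sapiens), with stated times of 10 min and 60 min (on this read-out lower numbers stand for stronger inhibition and higher numbers for weaker inhibition), compound 1 gives 36700 nM, the higher of the two. For the measured compounds named here, compound 2 `Oc1ccc(CNc2cc(C(F)(F)F)cc3[nH]ncc23)c(Cl)c1` carries chloro in place of hydrogen on an aromatic carbon, and in this assay compound 2 gives 6020 nM; the step of a 6.1-fold lower number from compound 1 to compound 2 (0.79 log units; beyond the scatter) is the one measured change on this core.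

Compound 3 `FC(F)(F)c1cc(NCc2cccc(Br)c2)c2cn[nH]c2c1` is not yet measured. Against compound 1 the change is 3-bromophenyl in place of 4-hydroxyphenyl on a saturated chain carbon bound to a nitrogen on an aromatic ring. Going by the values given here, no measured step exchanges the whole 4-hydroxyphenyl group; the only step that bears on the matter is the gain of a halogen on that ring in a 6.1-fold lower number from compound 1 to compound 2 (0.79 log units; beyond the scatter), a modest fall. Compound 3 also gains a halogen on the ring, bromine rather than chloro, but at the same time loses the hydroxyl, for which nothing is measured. A modest fall below compound 1, smaller than the chloro step and with wide uncertainty, is therefore expected. For compound 3 the expected step is a 3.1-fold lower number from compound 1 to compound 3 (0.49 log units; beyond the scatter). The estimate for compound 3 in this assay is 12000 nM, with a range from 3000 nM to 45000 nM.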

Compound 3, half-maximal inhibitory concentration: > 100000 nM
Compound 3 gave a limit, no number; the forecaster's own chance of this, stated with the estimate: 10%; middle value at least 8.3-fold (0.92 log units) from the limit.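

Compound 3 reads as a limit of the assay and not as a number, the only such reading in the series so far in this assay: the limit of > 100000 nM in this assay, at which 1 of the 3 values shown sits.

With 3-bromophenyl in place of 4-hydroxyphenyl on a saturated chain carbon bound to a nitrogen on an aromatic ring, the result is an at least 2.7-fold higher number from compound 1 to compound 3 (0.43 log units; beyond the scatter), which runs opposite to the earlier chloro step, a 6.1-fold lower number from compound 1 to compound 2 (0.79 log units; beyond the scatter). For the compounds shown here, a halogen on this ring therefore does not by itself give a lower number on the shared core, and the one lower number in hand belongs to compound 2, which keeps the hydroxyl.

The exchange in compound 3 removes the hydroxyl and brings in bromine in a single change, so the compounds shown cannot say how much of the step belongs to either part. Still open, as far as these compounds go, is how an unsubstituted phenyl, a 4-hydroxyphenyl that also carries bromine, or an amine or a carboxylic acid in place of the hydroxyl would read on this core.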